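Swapping a Methoxy for a Nitro on Compound 3

The source may report more compounds than this note shows. Statements on the series, on what has been measured and on what is new or still open speak of the compounds shown alone.

Of the compounds shown here, three built on one shared core have been tested in a functional assay on MDA-MB-231 cells (Homo sapiens) for cytotoxicity, read by MTT assay, with a stated time of 48 h; on this read-out higher numbers stand for weaker inhibition and lower numbers for stronger inhibition. Compound 1 `O=C1C[C@H](OCc2cn(-c3ccc(F)cc3)nn2)[C@H]2CO[C@@H]1O2` gives 23700 nM. Compound 2 `O=C1C[C@H](OCc2cc(-c3ccccc3)no2)[C@H]2CO[C@@H]1O2` gives 21900 nM in this assay, and compound 3 `COc1ccc(-c2cc(CO[C@H]3CC(=O)[C@@H]4OC[C@H]3O4)on2)cc1` gives 21900 nM. All three numbers lie within the usual scatter of one another, so none can be set apart: compound 3 stands level with compound 2, and its gap to compound 1 is too small to count.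

Compound 4 `O=C1C[C@H](OCc2cc(-c3ccc([N+](=O)[O-])cc3)no2)[C@H]2CO[C@@H]1O2` differs from compound 3 in a single place: nitro in place of methoxy on an aromatic carbon. Within the data shown here, the only measured step that touches this same position is no change at the digits printed from compound 2 to compound 3 (within the scatter), which shows that adding a methoxy there left the number where it was. Among the measured compounds shown here, no measured step involves a nitro, so nothing here speaks for a shift in either direction. Since the step of no change at the digits printed from compound 2 to compound 3 (within the scatter) was flat, no move beyond the scatter is expected in this assay for the step of a 1.0-fold higher number from compound 3 to compound 4 (0.00 log units; within the scatter). Compound 4 is therefore estimated at 22000 nM, within a range from 9000 nM to 55000 nM.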

Compound 4, half-maximal inhibitory concentration: 16500 nM
Beside the measured number, compound 4's estimate is 1.3-fold (0.12 log units) above it, and the stated range covers the measured number.
By their numbers in this assay, from the lowest: compounds 4, 2, 3 and 1 (each within the scatter of the next).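

In this assay the swap from methoxy to nitro reads a 1.3-fold lower number from compound 3 to compound 4 (0.12 log units; within the scatter) and the swap from hydrogen to nitro reads a 1.3-fold lower number from compound 2 to compound 4 (0.12 log units; within the scatter) so neither step can be told from repeat-to-repeat noise. Among these compounds, the earlier compounds gave only the step from hydrogen to methoxy at this place on the six-membered aromatic ring, para to a large group, whereas three different groups can now be compared there, and none of them sets its compound apart from the others. Nothing measured alongside these compounds offers an explanation for this flat result.

Still open, going by these compounds, is whether an amine or a carboxylic acid at this place would shift the number beyond the scatter. A longer chain such as butoxy in place of the methoxy leaves the same question open.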